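Changing the aryl group on a weakly active core

A few compounds are considered here, and "the series" means these few. Any claim that something is new, unique, unknown or untested is made for them only; others in the source may bear on it.

Measured so far in a functional assay on A549 cells (Homo sapiens) for antiproliferative activity, read by MTT assay, with a stated time of 72 h; a lower number here means a stronger inhibitor, a higher number a weaker inhibitor:
Compound 1 `COc1cc(C(=O)c2sc3ccccc3c2-c2ccccc2)cc(OC)c1OC`: 5000 nM
Compound 2 `COc1ccc(OC)c(-c2c(C(=O)c3cc(OC)c(OC)c(OC)c3)sc3ccccc23)c1`: > 10000 nM

Compound 2 reads > 10000 nM, which is a limit of the assay and not a number. Compound 3 `CCOc1ccc(-c2c(C(=O)c3cc(OC)c(OC)c(OC)c3)sc3ccccc23)cc1` differs from compound 2 in one place: 4-ethoxyphenyl in place of 2,5-dimethoxyphenyl on an aromatic carbon. The change is 4-ethoxyphenyl in place of 2,5-dimethoxyphenyl, on an aromatic carbon of a five-membered aromatic ring with 1 sulfur.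

Among the measured compounds shown here, one measured step bears on this carbon: an at least 2.0-fold higher number from compound 1 to compound 2 (0.30 log units; that floor lies within the scatter). On these data alone, it brought in the 2,5-dimethoxyphenyl group in place of phenyl, and it gives only a floor, so its true size remains unknown. For the measured compounds named here, no ethoxy compound has been measured. The expectation therefore rests on compound 1 with its 5000 nM, which shows that the shared core can give a number in this assay once the 2,5-dimethoxyphenyl group is gone. A modest move towards a lower number, meaning a stronger inhibitor, is expected: an at least 1.6-fold lower number from compound 2 to compound 3 (0.22 log units; that floor lies within the scatter). Compound 3 is estimated at 6000 nM, with an expected range of 1500 nM to 12000 nM.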

Compound 3, half-maximal inhibitory concentration: 3100 nM
For compound 3 the middle estimate is 1.9-fold (0.29 log units) above the measured one; the measured number falls inside the stated range.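

In this assay, the change at this aromatic carbon now gives a step that can be read as real. The move to the 4-ethoxyphenyl group (an at least 3.2-fold lower number from compound 2 to compound 3 (0.50 log units; beyond the scatter)) lies beyond the scatter, unlike the earlier step that brought in the 2,5-dimethoxyphenyl group. A phenyl group carrying an added group can therefore stay in the range of the plain phenyl group of compound 1, since ethoxy in place of hydrogen cannot be told apart from no change (a 1.6-fold lower number from compound 1 to compound 3 (0.21 log units; within the scatter)). The true size of the step to compound 3 remains unknown, and only its floor can be given, because compound 2 has a limit of the assay and not a number: the limit of > 10000 nM in this assay, at which 1 of the 3 values shown sits.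

What the compounds shown leave open is whether any group on this phenyl ring can separate itself from compound 1 by more than the scatter, as a longer chain such as butoxy, a carboxylic acid or an amine might or might not. They also leave open whether it is the ethoxy group or the loss of the 2,5-dimethoxy pattern that matters, as neither a 4-methoxyphenyl nor a 2-ethoxyphenyl group stands among them.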